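This account rests on a few compounds, and the source may have more. Where it says the series, first, only, none or still open, it means among the compounds named here.

In a functional assay on A2780 cells (Homo sapiens) for antiproliferative activity, read by MTT assay, with a stated time of 48 h (a higher number here means a weaker inhibitor of growth, a lower number a stronger inhibitor of growth), compound 1 `COC(=O)N1N=C(c2ccc(OC)cc2)CC1c1cc(OC)c(OC)c(OC)c1` gives 5000 nM as its measured value and compound 2 `CCCOC(=O)N1N=C(c2ccc(OC)cc2)CC1c1cc(OC)c(OC)c(OC)c1` gives 11700 nM there as well. Compound 3 `COc1ccc(C2=NN(C(=O)OCc3ccccc3)C(c3cc(OC)c(OC)c(OC)c3)C2)cc1` gives > 10000 nM in the same test, which is a limit and not a number. Compound 4 `COc1cc(C2CC(c3cccc(O)c3)=NN2C(=O)OCc2ccccc2)cc(OC)c1OC` keeps the benzyloxycarbonyl group of compound 3 and carries 3-hydroxyphenyl in place of 4-methoxyphenyl on a carbon with a double bond to nitrogen, with 3-hydroxyphenyl in place of 4-methoxyphenyl on a carbon with a double bond to nitrogen as the whole change. The measured steps are a 2.3-fold higher number from compound 1 to compound 2 (0.37 log units; beyond the scatter) and an at least 2.0-fold higher number from compound 1 to compound 3 (0.30 log units; that floor lies within the scatter) and a step that the limit leaves unreadable from compound 2 to compound 3 in this series. All of them concern the group on a saturated chain carbon bound to an oxygen next to a carbonyl group. None touches the 4-methoxyphenyl, so they give no size for this change. The only anchor is the limit of > 10000 nM in this assay, at which 1 of the 3 values shown sits, for compound 3, and no step beyond the scatter is expected in this assay in either direction. The expected step is a number no higher from compound 3 to compound 4 (the limit leaves the size open) on this reading. For compound 4 the estimate is 10000 nM with an expected range from 3000 nM to 30000 nM and an outcome that is only a limit remains possible.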

Compound 4, concentration for 50% growth inhibition: > 10000 nM
Compound 4 gave a limit, no number (the forecaster's own chance of this, stated with the estimate: 45%); the middle value sits exactly at the limit.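

In this assay compound 4 gives > 10000 nM, which is a limit and not a number. Within the data shown here, compound 3 also stands at a limit, so no step between compound 3 and compound 4 can be read. The compounds shown leave open how 3-hydroxyphenyl in place of 4-methoxyphenyl changes growth inhibition, in either direction.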